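This account rests on a few compounds, and the source may have more. Where it says the series, first, only, none or still open, it means among the compounds named here.

Compound 1 `COc1ccc(OC)c(/C=N/NC(=O)Nc2ccc(Oc3ccnc(-c4nncn4CCN(C)C)c3)c(F)c2)c1` carries a 2,5-dimethoxyphenyl on a carbon with a double bond to nitrogen. In a functional assay on A549 cells (Homo sapiens) for cytotoxicity, read by MTT assay, with a stated time of 72 h (a higher number here means a weaker inhibitor, a lower number a stronger inhibitor), compound 1 gives 1950 nM, the highest of the three numbers measured, with compound 3 close beside it. Compound 2 `CN(C)CCn1cnnc1-c1cc(Oc2ccc(NC(=O)N/N=C/c3c[nH]c4ccccc34)cc2F)ccn1` gives 820 nM, and compound 3 `CN(C)CCn1cnnc1-c1cc(Oc2ccc(NC(=O)N/N=C/c3ccc(F)cc3)cc2F)ccn1` gives 1790 nM. The steps that touch this position are a 2.4-fold lower number from compound 1 to compound 2 (0.38 log units; beyond the scatter) and a 1.1-fold lower number from compound 1 to compound 3 (0.04 log units; within the scatter), so changing the aryl group on that carbon has so far moved the number modestly at most. Compound 4 `COc1ccc(/C=N/NC(=O)Nc2ccc(Oc3ccnc(-c4nncn4CCN(C)C)c3)c(F)c2)cc1O` differs from compound 1 by 3-hydroxy-4-methoxyphenyl in place of 2,5-dimethoxyphenyl on a carbon with a double bond to nitrogen. Since both measured steps were small, the expected step is a 1.1-fold lower number from compound 1 to compound 4 (0.06 log units; within the scatter), within the scatter. Compound 4 is therefore estimated at 1700 nM, with a range from 700 nM to 4000 nM.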

Compound 4, half-maximal inhibitory concentration: > 100000 nM
Compound 4: no number, only a limit; the forecaster's own chance of this, stated with the estimate: 5%; middle value at least 58-fold (1.76 log units) from the limit.
By their numbers in this assay, from the lowest: compound 2; then compounds 3 and 1 (each within the scatter of the next). At a limit, above all of these: compound 4.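

Compound 4 gives no number, only a limit: the limit of > 100000 nM in this assay, at which 1 of the 4 values shown sits. Even so, the steps to it are far larger than any among the first three compounds: an at least 51-fold higher number from compound 1 to compound 4 (1.70 log units; beyond the scatter), an at least 55-fold higher number from compound 3 to compound 4 (1.74 log units; beyond the scatter) and an at least 120-fold higher number from compound 2 to compound 4 (2.08 log units; beyond the scatter). This position therefore does not accept every aryl group equally, and 3-hydroxy-4-methoxyphenyl, the only group shown with a hydrogen-bond donor on a carbon-only aromatic ring, stands apart from 2,5-dimethoxyphenyl and 4-fluorophenyl.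

On these data alone, whether the hydroxy group itself or the arrangement of the two oxygens matters remains open. A 3,4-dimethoxyphenyl or a 3-amino-4-methoxyphenyl group at this position could separate the two.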